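The source may report more compounds than this note shows. Statements on the series, on what has been measured and on what is new or still open speak of the compounds shown alone.

Compound 1 `CCCN(C)c1cc(C)nc2c(-c3ccc(Cl)cc3Cl)nn(C)c12` gives 24 nM in an assay on HEK293 cells for displacement of a labelled ligand from corticotropin-releasing factor receptor 1 (Homo sapiens); a lower number here means a stronger inhibitor, a higher number a weaker inhibitor. Compound 2 `CCCN(CC)c1cc(C)nc2c(-c3ccc(Cl)cc3Cl)nn(C)c12` gives 4.1 nM in this assay, and compound 3 `CCCCN(CCCC)c1cc(C)nc2c(-c3ccc(Cl)cc3Cl)nn(C)c12` gives 0.62 nM, the lowest of the three numbers. The steps of a 5.9-fold lower number from compound 1 to compound 2 (0.77 log units; beyond the scatter) and a 6.6-fold lower number from compound 2 to compound 3 (0.82 log units; beyond the scatter) both ran toward lower numbers as the amino group gained carbons, and a 39-fold lower number from compound 1 to compound 3 (1.59 log units; beyond the scatter) was larger still. Compound 4 `CCCCCN(CCC)c1cc(C)nc2c(-c3ccc(Cl)cc3Cl)nn(C)c12` carries pentyl(propyl)amino in place of dibutylamino on an aromatic carbon. Here nothing is added or removed; only the chain lengths are redistributed between the two arms. Going by the values given here, no measured step tests such a rearrangement at fixed size. Since a 6.6-fold lower number from compound 2 to compound 3 (0.82 log units; beyond the scatter) and a 5.9-fold lower number from compound 1 to compound 2 (0.77 log units; beyond the scatter) were only modest even with added atoms, the step of a 1.3-fold higher number from compound 3 to compound 4 (0.11 log units; within the scatter) is expected to remain within the scatter. Compound 4 is estimated at 0.8 nM, with a range from 0.3 nM to 2.5 nM.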

Compound 4, inhibition constant: 1.2 nM
For compound 4 the middle estimate is 1.5-fold (0.18 log units) below the measured one, within the range that was stated.
By their numbers in this assay, from the lowest: compounds 3 and 4 (each within the scatter of the next); then compound 2; then compound 1.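

With the size held fixed, a 1.9-fold higher number from compound 3 to compound 4 (0.29 log units; within the scatter) shows that moving carbon between the two arms of the amino group on this aromatic carbon gives no separable difference in this assay. Going by these compounds alone, compound 4 also stays apart from the smaller amino groups, with a 3.4-fold lower number from compound 2 to compound 4 (0.53 log units; beyond the scatter) and a 20-fold lower number from compound 1 to compound 4 (1.30 log units; beyond the scatter), so across these four compounds the total carbon count follows the numbers, with no compound against it. Nothing available explains this result.

Still open, as far as these compounds go, are a more uneven split such as hexyl(ethyl)amino and branched arms such as diisobutylamino. From the compounds shown here alone, a ring amine such as piperidine at this position is also open.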